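Diamino core series: fluoro to methoxy on the thioether aryl

The source may report more compounds than this note shows. Statements on the series, on what has been measured and on what is new or still open speak of the compounds shown alone.

Measured so far in a functional assay on U-251 cells (Homo sapiens) for inhibition, read by sulforhodamine B assay, with a stated time of 48 h; on this read-out lower numbers stand for stronger inhibition of growth and higher numbers for weaker inhibition of growth:
- compound 1 `CCOC(=O)[C@H](CCC(=O)O)NC(=O)c1ccc(Sc2nc3cc(N)cc(N)c3nc2-c2ccccc2)cc1`: 14500 nM
- compound 2 `Nc1cc(N)c2nc(-c3ccccc3)c(Sc3ccc(F)cc3)nc2c1`: 16200 nM
- compound 3 `COc1ccc(CNc2nc3cc(N)cc(N)c3nc2-c2ccccc2)cc1`: 13500 nM

All three numbers sit close together. Compound 2 gives the highest of the three, but its gap to compound 1 and its gap to compound 3 both lie within the usual scatter, so no order among compounds 1, 2 and 3 can be read from these values; the shared core with a phenyl group appears to set the level, and the variations on the other arm have not moved it beyond noise.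

Compound 4 `COc1ccc(Sc2nc3cc(N)cc(N)c3nc2-c2ccccc2)cc1` has not been measured. It differs from compound 2 in one place: methoxy in place of fluoro on an aromatic carbon. The change is on an aromatic carbon of a six-membered aromatic ring of carbon only, para to a large group.

Compound 3, which also carries a methoxy on its aryl group though attached through a different linker, gives a value that does not separate from compound 2, so nothing in the measured set points to a shift. The step from compound 2 to compound 4 is expected to stay within the scatter: a 1.2-fold lower number from compound 2 to compound 4 (0.06 log units; within the scatter). On that basis compound 4 is estimated at 14000 nM, with a likely range from 6000 nM to 35000 nM.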

Compound 4, concentration for 50% growth inhibition: < 100000 nM
Compound 4: no number, only a limit (the forecaster's own chance of this, stated with the estimate: 5%); the middle value is on the limit's open side.
By their numbers in this assay, from the lowest: compounds 3, 1 and 2 (each within the scatter of the next).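

In this assay, within the data shown here, compound 4 returns only a limit of < 100000 nM and no number, so no step from compound 2 to compound 4 can be read. On these data alone, whether methoxy in place of fluoro on an aromatic carbon changes the read-out in this assay at all, and in which direction, stays open.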